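A Cyclopentylmethyl Group on a Weak Inhibitor

The compounds below may be only part of what the source reports. "The series", "measured", "known", "first", "only" and "open" are said of these compounds alone.

In a functional assay on DU-145 cells (Homo sapiens) for inhibition, read by trypan blue exclusion, with a stated time of 72 h (a lower number here means a stronger inhibitor, a higher number a weaker inhibitor), compound 1 `COC(=O)Cn1c(=O)c(S(=O)(=O)c2ccc(F)cc2F)cc2cnc(Nc3ccc4[nH]ccc4c3)nc21` gives 10000 nM and compound 2 `O=c1[nH]c2nc(Nc3ccc4[nH]ccc4c3)ncc2cc1S(=O)(=O)c1ccc(F)cc1F` gives 15000 nM. For the measured compounds named here, compound 2 therefore stands level with the only other measured compound, since the two numbers lie within the scatter of each other.

Compound 3 `O=c1c(S(=O)(=O)c2ccc(F)cc2F)cc2cnc(Nc3ccc4[nH]ccc4c3)nc2n1CC1CCCC1` has not been measured yet. It has cyclopentylmethyl in place of hydrogen on an aromatic nitrogen of compound 2: cyclopentylmethyl in place of hydrogen on an aromatic nitrogen.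

Going by the values given here, only one measured step bears on this nitrogen, a 1.5-fold higher number from compound 1 to compound 2 (0.18 log units; within the scatter), where hydrogen replaces (methoxycarbonyl)methyl. Among the compounds with values here, with that small step as the only guide, no step beyond the scatter is expected in this assay. A single pair offers thin support, and no group made only of carbon has been measured here, so the range stays wide. The expected change is a 1.5-fold lower number from compound 2 to compound 3 (0.18 log units; within the scatter). For compound 3 the estimated value is 10000 nM, with an expected range from 4000 nM to 25000 nM.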

Compound 3, half-maximal inhibitory concentration: 10000 nM
The estimate for compound 3 equals the measured number at the digits printed; the range from low to high includes it.
By their numbers in this assay, from the lowest: compounds 1, 3 and 2 (each within the scatter of the next).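

In this assay, placing a group made only of carbon on this aromatic nitrogen gives a 1.5-fold lower number from compound 2 to compound 3 (0.18 log units; within the scatter). Cyclopentyl in place of methoxycarbonyl on the saturated chain carbon gives no change at the digits printed from compound 1 to compound 3 (within the scatter), so hydrogen, (methoxycarbonyl)methyl and cyclopentylmethyl on this nitrogen cannot be told apart in this assay, and a ring of carbon here brings no step beyond the scatter. Nothing available explains why these three groups read alike.

Going by these compounds, whether an amine or a carboxylic acid at the end of a longer chain on this nitrogen would give a clearly different number remains open. Also open, on these data alone, is whether changing the (2,4-difluorophenyl)sulfonyl group, rather than this nitrogen, would move the number beyond the scatter.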